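The compounds below may be only part of what the source reports. "The series", "measured", "known", "first", "only" and "open" are said of these compounds alone.

Compound 1 `c1ccc(CN(CCCN2CCCCC2)c2cc(-c3ccccc3)no2)cc1` — 9000 nM
Compound 2 `Clc1cccc(CN(CCCN2CCCCC2)c2cc(-c3ccccc3)no2)c1` — 1000 nM
Compound 3 `COc1cccc(CN(CCCN2CCC2)c2cc(-c3ccccc3)no2)c1` — a limit, > 10000 nM
Compound 4 `COc1cccc(CN(CCCN2CCCC2)c2cc(-c3ccccc3)no2)c1` — not yet measured

Among the compounds with values here, in a functional assay for antagonist activity at proteinase-activated receptor 1 (Homo sapiens) (on this read-out higher numbers stand for weaker inhibition and lower numbers for stronger inhibition), compound 1 gives 9000 nM and compound 2 gives 1000 nM; the single step between them, a 9.0-fold lower number from compound 1 to compound 2 (0.95 log units; beyond the scatter), is the only measured step the set affords. For compound 3 the assay reports only a limit, > 10000 nM (the limit of > 10000 nM in this assay, at which 1 of the 3 values shown sits). Compound 3 therefore stands at the weak end of what has been seen, without a number of its own.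

Compound 4 differs from compound 3 in one place: pyrrolidin-1-yl in place of azetidin-1-yl on a saturated chain carbon, three bonds along the chain from a nitrogen on an aromatic ring. Within the data shown here, no measured step concerns this change. Among the measured compounds shown here, the one known step, from compound 1 to compound 2, is a chloro in place of hydrogen on an aromatic carbon and does not touch the part that changes here, and compounds 1 and 2 differ from compound 3 in more than one place, so their values cannot be read across. The expected step in this assay is accordingly unknown in size, and no shift beyond the scatter is anticipated: a number no higher from compound 3 to compound 4 (the limit leaves the size open). Compound 4 is estimated at 10000 nM, in the range 3000 nM to 30000 nM, with a fair chance that it too is reported only as a limit.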

Compound 4, half-maximal inhibitory concentration: 3300 nM
Estimate against measurement, compound 4: 3.0-fold (0.48 log units) above; low and high end bracket the measured number.
By their numbers in this assay, from the lowest: compound 2; then compound 4; then compound 1. At a limit, above all of these: compound 3.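

Within the data shown here, this is the first view of what the group at the far end of the chain does, as the earlier step touched only a chloro on an aromatic carbon. In this assay, pyrrolidin-1-yl in place of azetidin-1-yl, on a saturated chain carbon, three bonds along the chain from a nitrogen on an aromatic ring, gives an at least 3.0-fold lower number from compound 3 to compound 4 (0.48 log units; beyond the scatter), so the read-out responds to the ring at this place, and the five-membered ring brings a measurable number where the four-membered ring gave none. The true size of the step is open on one side, since compound 3 is held only at a limit: the limit of > 10000 nM in this assay, at which 1 of the 4 values shown sits.

The compounds shown leave open whether the trend runs on to piperidin-1-yl at this place on the core of compound 4, and what an open-chain dimethylamino group or a morpholin-4-yl ring would do there. They also leave open whether chloro on the benzene ring of compound 4, in place of its methoxy, would bring the same kind of gain as a 9.0-fold lower number from compound 1 to compound 2 (0.95 log units; beyond the scatter).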